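Pyrimidin-5-yl in Place of Phenyl at the Core

The source may report more compounds than this note shows. Statements on the series, on what has been measured and on what is new or still open speak of the compounds shown alone.

Compound 2 `O=C(CCCCCCc1nc2ccc(-c3ccccc3)cc2[nH]1)NO` stands lowest of the three numbers in a functional assay on SK-OV-3 cells (Homo sapiens) for cytotoxicity (a lower number here means a stronger inhibitor, a higher number a weaker inhibitor), with 100 nM. Compound 1 `O=C(CCCCCCc1nc2ccccc2[nH]1)NO` gives 2700 nM and compound 3 `O=C(CCCCCCc1nc2ccc(-c3cccc(F)c3)cc2[nH]1)NO` gives 1500 nM. Among the measured compounds shown here, two steps bear on the change: a 27-fold lower number from compound 1 to compound 2 (1.43 log units; beyond the scatter) and a 15-fold higher number from compound 2 to compound 3 (1.18 log units; beyond the scatter), both large and beyond the scatter, showing that this assay answers strongly to what sits at that position. Compound 4 `O=C(CCCCCCc1nc2ccc(-c3cncnc3)cc2[nH]1)NO` carries the change (pyrimidin-5-yl in place of phenyl on an aromatic carbon). Since a single fluoro already cost a large step, the exchange of the whole ring is expected to cost as well, though the direction is not secured by any measured pair. Compound 4 is therefore expected to give a higher number, as a 6.0-fold higher number from compound 2 to compound 4 (0.78 log units; beyond the scatter). The estimate for compound 4 is 600 nM, within 150 nM to 2500 nM.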

Compound 4, half-maximal inhibitory concentration: 2600 nM
For compound 4 the middle estimate is 4.3-fold (0.64 log units) below the measured one, outside the stated range (above it).
By their numbers in this assay, from the lowest: compound 2; then compounds 3, 4 and 1 (each within the scatter of the next).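

Pyrimidin-5-yl in place of phenyl gives back the whole gain that phenyl brought (a 26-fold higher number from compound 2 to compound 4 (1.41 log units; beyond the scatter)), so this ring exchange is not tolerated at this position. The steps from hydrogen (a 1.0-fold lower number from compound 1 to compound 4 (0.02 log units; within the scatter)) and from 3-fluorophenyl (a 1.7-fold higher number from compound 3 to compound 4 (0.24 log units; within the scatter)) both lie within the scatter, leaving unsubstituted phenyl as the only group shown that stands apart. Nothing at hand accounts for this. From the compounds shown here alone, whether a pyridinyl ring or a methoxyphenyl group would keep the number of phenyl stays open.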